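The source may report more compounds than this note shows. Statements on the series, on what has been measured and on what is new or still open speak of the compounds shown alone.

Compound 1 `Oc1ccc(-c2cc(-c3cccc(O)c3)cc(-c3cccc(O)c3)n2)cc1` is built on a six-membered aromatic ring with one nitrogen carrying three phenol rings. In a functional assay on DU-145 cells (Homo sapiens) for cytotoxicity, read by CCK-8 assay, with a stated time of 4 days (a higher number here means a weaker inhibitor, a lower number a stronger inhibitor), compound 1 gives 1940 nM. Compound 2 `Oc1cccc(-c2cc(-c3cccc(O)c3)nc(-c3cccc(O)c3)c2)c1` differs from it at one point (3-hydroxyphenyl in place of 4-hydroxyphenyl on an aromatic carbon), and in this assay compound 2 gives 4040 nM; the step is a 2.1-fold higher number from compound 1 to compound 2 (0.32 log units; beyond the scatter). Compound 3 `Oc1ccc(-c2cc(-c3ccccc3O)cc(-c3ccccc3O)n2)cc1` has the same atoms joined differently, with the two outer phenols now 2-hydroxyphenyl groups; the difference between the core of compound 1 and the core of compound 3 is not broken down here. In this assay compound 3 gives 360 nM, the lowest of the three numbers, and its steps to compound 1 and compound 2 both lie beyond the scatter.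

Compound 4 `Oc1cccc(-c2cc(-c3ccccc3O)cc(-c3ccccc3O)n2)c1` stands to compound 3 as compound 2 stands to compound 1 (3-hydroxyphenyl in place of 4-hydroxyphenyl on an aromatic carbon). The surroundings are not identical: in the first pair the changed carbon is meta to two 3-hydroxyphenyl groups, in the second it is meta to two 2-hydroxyphenyl groups, so this is the same kind of change rather than the same change. Because the earlier step was a 2.1-fold higher number from compound 1 to compound 2 (0.32 log units; beyond the scatter), the step from compound 3 to compound 4 in this assay is expected to be of similar size, a 2.1-fold higher number from compound 3 to compound 4 (0.32 log units; beyond the scatter), with wider uncertainty since the flanking groups differ. Compound 4 is therefore estimated at 760 nM in this assay, expected to fall between 350 nM and 1700 nM.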

Compound 4, half-maximal inhibitory concentration: 3980 nM
Compound 4: middle estimate off by 5.2-fold (0.72 log units), on the low side, outside the stated range (above it).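

In this assay the exchange of 4-hydroxyphenyl for 3-hydroxyphenyl gives an 11-fold higher number from compound 3 to compound 4 (1.04 log units; beyond the scatter) on the core of compound 3, and set beside the same exchange on the core of compound 1, the size of the step does not carry over: the same change on two cores in this assay, a 2.1-fold higher number (0.32 log units; beyond the scatter) from compound 1 to compound 2 and an 11-fold higher number (1.04 log units; beyond the scatter) from compound 3 to compound 4, 5.3-fold (0.73 log units) apart, beyond the scatter of two such steps. The direction does carry over in these two pairs, since the number rises on both cores, but the size of the step on one core gave no reliable measure of its size on the other. Among these compounds, with only two pairs, this does not show which feature of the two cores sets the size of the step, nor what size the step would take on any further core.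

Every compound shown carries three phenol rings, so how an amine or a carboxylic acid in place of a hydroxyl group would fare in this assay stays open. On these data alone, it also stays open whether the same exchange would give a step like either of these two with other outer groups, such as two methoxyphenyl groups in place of the two 2-hydroxyphenyl groups.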